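One Fluoro Added to the Most Potent of Three

The compounds below may be only part of what the source reports. "The series", "measured", "known", "first", "only" and "open" are said of these compounds alone.

Of the compounds shown here, three sharing one core have been measured in a functional assay on MGC-803 cells (Homo sapiens) for antiproliferative activity, read by CellTiter-Glo, with a stated time of 72 h; on this read-out lower numbers stand for stronger inhibition and higher numbers for weaker inhibition. There, compound 1 `O=C(NO)c1ccc(/C=C/c2ccnc(-c3cc(F)ccc3O)c2)cc1` gives 1920 nM and compound 2 `O=C(NO)c1ccc(/C=C/c2ccnc(-c3cccnc3)c2)cc1` gives 4550 nM. Compound 3 `Cc1ccc(-c2cc(/C=C/c3ccc(C(=O)NO)cc3)ccn2)c(F)c1` gives 770 nM, the lowest number of the three and clearly separated from both others.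

Compound 4 `Cc1ccc(-c2cc(/C=C/c3ccc(C(=O)NO)cc3)c(F)cn2)c(F)c1` departs from compound 3 by a single change, fluoro in place of hydrogen on an aromatic carbon of a six-membered aromatic ring with 1 nitrogen, para to a 2-fluoro-4-methylphenyl group.

Among the measured compounds shown here, no measured step makes this change. Each one exchanges a single aromatic group for another, giving a 2.5-fold lower number from compound 1 to compound 3 (0.40 log units; beyond the scatter), a 2.4-fold higher number from compound 1 to compound 2 (0.37 log units; beyond the scatter) and a 5.9-fold lower number from compound 2 to compound 3 (0.77 log units; beyond the scatter). These steps bear on it only indirectly. All three are modest, even though each replaces a whole aromatic group, and the change in compound 4 is one atom. The data contain no direct evidence on its direction, so no step beyond the scatter is expected in this assay, with only a slight lean towards a higher number.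

The expected change is a 1.2-fold higher number from compound 3 to compound 4 (0.07 log units; within the scatter). Compound 4 is estimated at 900 nM, with an expected range from 350 nM to 2300 nM.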

Compound 4, half-maximal inhibitory concentration: 2510 nM
Beside the measured number, compound 4's estimate is 2.8-fold (0.45 log units) below it; the whole stated range lies below it.
By their numbers in this assay, from the lowest: compound 3; then compounds 1, 4 and 2 (each within the scatter of the next, the first and the last beyond it).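

The carbon ortho to a large group, two atoms from the ring nitrogen and para to a 2-fluoro-4-methylphenyl group, proves sensitive in this assay: fluoro in place of hydrogen there gives a 3.3-fold higher number from compound 3 to compound 4 (0.51 log units; beyond the scatter). The earlier compounds shown here varied only the aromatic group and left this carbon untouched, so they could not show that a change of one atom on the other side of that group would move the number beyond the scatter, and in the direction of weaker inhibition. This step is modest, the same label carried by the exchanges of whole aromatic groups, and nothing available offers an explanation for it.

The compounds shown leave open whether the step belongs to fluoro itself or would also appear with another substituent on this carbon, such as chloro, methyl, methoxy or an amine. They also leave open whether the same fluoro would give a similar step alongside the pyridin-3-yl or 5-fluoro-2-hydroxyphenyl group in place of 2-fluoro-4-methylphenyl.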